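Ortho hydroxy in place of fluoro on the aryl ether

The compounds below may be only part of what the source reports. "The series", "measured", "known", "first", "only" and "open" are said of these compounds alone.

The series shares one core and varies the aryl group on the ether oxygen. Compound 1 `CC(C)(Oc1ccccc1)C1OCC(C/C=C\CCC(=O)O)C(c2cccnc2)O1` carries a plain phenyl and in an assay for inhibition of Thromboxane-A synthase (Homo sapiens), using microsomes (a lower number here means a stronger inhibitor, a higher number a weaker inhibitor), compound 1 gives 52 nM. Compound 2 `Cc1ccc(OC(C)(C)C2OCC(C/C=C\CCC(=O)O)C(c3cccnc3)O2)cc1` carries a 4-methylphenyl, and compound 2 gives 360 nM. Compound 3 `CC(C)(Oc1ccccc1F)C1OCC(C/C=C\CCC(=O)O)C(c2cccnc2)O1` carries a 2-fluorophenyl, and compound 3 gives 45 nM, the lowest of the three numbers, though the two values of compound 1 and compound 3 lie within the scatter of each other; only compound 2 sits clearly apart, with an 8.0-fold lower number from compound 2 to compound 3 (0.90 log units; beyond the scatter).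

Compound 4 `CC(C)(Oc1ccccc1O)C1OCC(C/C=C\CCC(=O)O)C(c2cccnc2)O1` follows from compound 3 by hydroxy in place of fluoro on an aromatic carbon. For the measured compounds named here, two measured steps touch on this position of the aryl ring. The step of a 1.2-fold lower number from compound 1 to compound 3 (0.06 log units; within the scatter) shows that a fluoro there is not felt. The step of a 6.9-fold higher number from compound 1 to compound 2 (0.84 log units; beyond the scatter) shows that a methyl elsewhere on the ring costs potency. Going by the values given here, no measured step puts a hydroxy on the ring, so the new donor and acceptor are untested, and the measured steps give no ground for expecting more than a small loss. The expectation for compound 4 is therefore a 1.8-fold higher number from compound 3 to compound 4 (0.25 log units; within the scatter), a step no larger than the scatter allows, with a wide range. Compound 4 is estimated at 80 nM, between 25 nM and 300 nM.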

Compound 4, half-maximal inhibitory concentration: 32 nM
Estimate against measurement, compound 4: 2.5-fold (0.40 log units) above; the range from low to high includes it.
By their numbers in this assay, from the lowest: compounds 4, 3 and 1 (each within the scatter of the next); then compound 2.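

In this assay, this aromatic carbon, ortho to a large group, takes a hydroxy, with one hydrogen-bond donor and one hydrogen-bond acceptor, as readily as a fluoro, which has neither (a 1.4-fold lower number from compound 3 to compound 4 (0.15 log units; within the scatter)), and the same holds against the unsubstituted phenyl (a 1.6-fold lower number from compound 1 to compound 4 (0.21 log units; within the scatter)). Hydrogen, fluoro and hydroxy at this carbon therefore cannot be told apart in compound 1, compound 3 and compound 4, so the tolerance seen with fluoro is not confined to a group without hydrogen-bond donors or acceptors, while the 2-hydroxyphenyl and 4-methylphenyl ethers remain clearly separated (an 11-fold lower number from compound 2 to compound 4 (1.05 log units; beyond the scatter)). Nothing available explains why the hydroxy is accepted here.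

Still open, on these data alone, is whether a methoxy, an amine or a carboxylic acid at this same carbon would be accepted in the same way as the hydroxy. Also open, as far as these compounds go, is whether the loss seen with compound 2 belongs to the methyl itself or to where it sits, which a methyl on the carbon carrying the hydroxy in compound 4 would separate.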